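The compounds below may be only part of what the source reports. "The series", "measured", "known", "first", "only" and "open" are said of these compounds alone.

Measured so far:
compound 1, `CCCCCC(=O)N1CCN(c2nnc3nncn3n2)CC1`: 5260 nM
compound 2, `CN(C)c1nnc2nncn2n1`: 7760 nM

The study measures inhibition in a functional assay on MCF7 cells (Homo sapiens) for inhibition, read by MTT assay, with a stated time of 72 h; a higher number here means a weaker inhibitor, a lower number a stronger inhibitor. In this assay compound 1 gives 5260 nM, and compound 2 gives 7760 nM. The two numbers lie within the usual scatter of each other, so neither compound can be called the stronger or the weaker on this evidence; compound 1 simply has one of two closely matched values.

Compound 3, `CN1CCN(c2nnc3nncn3n2)CC1`, has not yet been measured. It differs from compound 1 in one place: methyl in place of pentylcarbonyl on an amine nitrogen in a ring. Among the compounds with values here, no measured pair shows this exact change, so its size must be expected rather than read off. Compound 2, which also carries only methyl groups on its amine nitrogen and gives 7760 nM, suggests that the loss of the pentylcarbonyl need not move the number far. Compound 3 is therefore expected to give 8000 nM, within 2500 nM to 25000 nM. This estimate means a step of a 1.5-fold higher number from compound 1 to compound 3 (0.18 log units; within the scatter), expected to stay within the scatter or only slightly beyond it toward weaker inhibition.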

Compound 3, half-maximal inhibitory concentration: 21600 nM
Compound 3: middle estimate off by 2.7-fold (0.43 log units), on the low side; low and high end bracket the measured number.
By their numbers in this assay, from the lowest: compounds 1 and 2 (each within the scatter of the next); then compound 3.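

In this assay, within the data shown here, methyl in place of pentylcarbonyl on the amine nitrogen of the six-membered ring gives a 4.1-fold higher number from compound 1 to compound 3 (0.61 log units; beyond the scatter) and is the only step here that lies beyond the scatter. This position therefore responds to the group it carries: with the rest of the molecule unchanged, pentylcarbonyl goes with the lower number and methyl with the higher. Nothing measured here accounts for the step.

The change removes the carbonyl and shortens the chain at once, so these compounds cannot show which of the two goes with the step. On these data alone, it remains open whether a hexyl chain on this nitrogen, without a carbonyl, or an acetyl group, which keeps the carbonyl on a short chain, would stay near compound 1 or near compound 3.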